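Working notes: amino for methoxy on the anilino ring

The compounds below may be only part of what the source reports. "The series", "measured", "known", "first", "only" and "open" are said of these compounds alone.

Compound 1 `COc1ccc(Nc2nc(-c3cccc(F)c3)nc3ccc(F)cc23)cc1` stands alone in this series with a numerical result in a functional assay on U-937 cells (Homo sapiens) for cytotoxicity, read by MTT assay, with a stated time of 48 h (on this read-out higher numbers stand for weaker inhibition and lower numbers for stronger inhibition), where compound 1 gives 41100 nM. Compound 2 `Fc1cccc(-c2nc(Nc3ccccc3Cl)c3cc(F)ccc3n2)c1` reaches only a limit of the assay, > 50000 nM. Compound 3 `Fc1cccc(-c2nc(Nc3ccccc3Br)c3cc(F)ccc3n2)c1` likewise reaches only a limit, > 50000 nM. The steps of an at least 1.2-fold higher number from compound 1 to compound 2 (0.08 log units; that floor lies within the scatter) and an at least 1.2-fold higher number from compound 1 to compound 3 (0.08 log units; that floor lies within the scatter) therefore carry little information, and the step that the two limits leave unreadable from compound 2 to compound 3 cannot be read since both values sit at the limit of > 50000 nM in this assay, at which 2 of the 3 values shown sit.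

Compound 4 `Nc1ccc(Nc2nc(-c3cccc(F)c3)nc3ccc(F)cc23)cc1` differs from compound 1 in one place: amino in place of methoxy on an aromatic carbon. Among the measured compounds shown here, none of the measured steps bears directly on this change; each of them exchanges the whole ring on the nitrogen, and none alters a single group on the 4-methoxyphenyl while keeping the rest of it. For the measured compounds named here, the only guidance is that compound 1 itself lies close to the limit, so a small drift in either direction could push compound 4 past it. No step beyond the scatter is expected; compound 4 is estimated at 38000 nM, between 13000 nM and 110000 nM. This estimate means an expected step of a 1.1-fold lower number from compound 1 to compound 4 (0.03 log units; within the scatter), within the scatter.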

Compound 4, half-maximal inhibitory concentration: > 50000 nM
Compound 4 was reported as a limit; the forecaster's own chance of this, stated with the estimate: 40%; at least 1.3-fold (0.11 log units) between middle value and limit.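

Here a single group on the 4-methoxyphenyl is exchanged with the rest of the molecule held, and this assay reads an at least 1.2-fold higher number from compound 1 to compound 4 (0.08 log units; that floor lies within the scatter). Going by these compounds, that step is only a floor, so amino in place of methoxy at this place, para to a large group, gives no sign of stronger inhibition, while the true size of any weakening stays unknown. The steps from compound 2 and from compound 3 to compound 4 cannot be read, and most of the series now rests on a single limit: the limit of > 50000 nM in this assay, at which 3 of the 4 values shown sit.

Open, on these data alone, is whether any other group at this place would give a number on the lower side of compound 1, for instance hydroxy, dimethylamino or an acetamide. Among the compounds shown here, also open is how an ethoxy or a plain phenyl on the nitrogen would read against compound 1, whose 41100 nM is the only number.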